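Ester variation on a carbonyl carbon of the shared core

The compounds below may be only part of what the source reports. "The series", "measured", "known", "first", "only" and "open" are said of these compounds alone.

Compound 1 `CC(=O)O[C@H]1CC[C@]2(C)[C@H](CC[C@@](C)(O)[C@H]2CC[C@@H]2C(C)=CC[C@H]3[C@H](CC[C@]3(C)O)C2(C)C)OC1(C)C` is measured in a functional assay on MDA-MB-231 cells (Homo sapiens) for antiproliferative activity, read by MTT assay, with a stated time of 72 h (a higher number here means a weaker inhibitor, a lower number a stronger inhibitor), at 38000 nM, the highest of the three numbers in hand, though its gaps to compound 3 and to compound 2 both lie within the scatter. Compound 2 `CC1=CC[C@H]2[C@@H]1CC=C(C)[C@@H](CC[C@H]1[C@]3(C)CC[C@H](OC(=O)CCC(=O)O)C(C)(C)O[C@H]3CC[C@@]1(C)O)C2(C)C` gives 29600 nM in this assay. Compound 3 `CC1=CC[C@H]2[C@@H]1CC=C(C)[C@@H](CC[C@H]1[C@]3(C)CC[C@H](OC(=O)c4ccc(C)cc4)C(C)(C)O[C@H]3CC[C@@]1(C)O)C2(C)C` gives 32700 nM in this assay. For the measured compounds named here, the only single-point step available, a 1.1-fold higher number from compound 2 to compound 3 (0.04 log units; within the scatter), shows that swapping the group on a carbonyl carbon leaves the number essentially unchanged. Compound 4 `CC1=CC[C@H]2[C@H](CC[C@]2(C)O)C(C)(C)[C@@H]1CC[C@H]1[C@]2(C)CC[C@H](OC(=O)c3ccc([N+](=O)[O-])cc3)C(C)(C)O[C@H]2CC[C@@]1(C)O` differs from compound 1 by 4-nitrophenyl in place of methyl on a carbonyl carbon. This again touches only the ester group, so no step beyond the scatter is expected in this assay. The expected step is a 1.1-fold lower number from compound 1 to compound 4 (0.02 log units; within the scatter). Compound 4 is accordingly estimated at 36000 nM, within a range of 18000 nM to 72000 nM.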

Compound 4, half-maximal inhibitory concentration: 8900 nM
Compound 4: the middle estimate sits 4.0-fold (0.61 log units) above what was measured; the measured number lies below the stated range.
By their numbers in this assay, from the lowest: compound 4; then compounds 2, 3 and 1 (each within the scatter of the next).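

For the compounds shown here, the ester position is not silent in this assay: a 4.3-fold lower number from compound 1 to compound 4 (0.63 log units; beyond the scatter) is the first step here beyond the scatter, whereas a 1.1-fold higher number from compound 2 to compound 3 (0.04 log units; within the scatter) stayed within it. An aromatic ring on this carbonyl carbon is not enough by itself, as compound 3 with 4-methylphenyl gives 32700 nM against compound 4 at 8900 nM in the same assay. No measurement at hand bears on the origin of this step.

Open, from the compounds shown here alone, is whether a 4-aminophenyl or 4-methoxyphenyl ester would match compound 4. Also open, going by these compounds, is whether an amide in place of the ester would keep its number.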